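The compounds below may be only part of what the source reports. "The series", "measured", "known", "first", "only" and "open" are said of these compounds alone.

Compound 1 `CCOC(=O)C1=C(C)NC(C)=C(C(=O)OC)C1c1csc(-c2ccc(Cl)cc2)n1` gives 22000 nM in an assay on isolated protein for antagonist activity at Voltage-dependent L-type calcium channel subunit alpha-1C (Cavia porcellus), with a stated time of 15 min; on this read-out higher numbers stand for weaker inhibition and lower numbers for stronger inhibition.
Compound 2 `COC(=O)C1=C(C)NC(C)=C(C(=O)OCC(C)C)C1c1csc(-c2ccc(Cl)cc2)n1` gives 46900 nM in this assay.

Compound 1 stands at the lower of these two numbers. Compound 3 `CCOC(=O)C1=C(C)NC(C)=C(C(=O)OC2CCCC2)C1c1csc(-c2ccc(Cl)cc2)n1` has not been measured; it differs from compound 1 by cyclopentyl in place of methyl on an oxygen next to a carbonyl group. For the measured compounds named here, only one measured step bears on this change: a 2.1-fold higher number from compound 1 to compound 2 (0.33 log units; beyond the scatter), which also put a larger group in place of methyl on the same ester oxygen and gave a modest weakening. Because that step a 2.1-fold higher number from compound 1 to compound 2 (0.33 log units; beyond the scatter) went in that direction, a step of similar size toward weaker inhibition is expected for compound 3, a 1.8-fold higher number from compound 1 to compound 3 (0.26 log units; within the scatter). Compound 3 is therefore estimated at 40000 nM, with a range from 15000 nM to 110000 nM.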

Compound 3, half-maximal inhibitory concentration: 8380 nM
Compound 3: the middle estimate sits 4.8-fold (0.68 log units) above what was measured; the whole stated range lies above it.
By their numbers in this assay, from the lowest: compound 3; then compound 1; then compound 2.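

Cyclopentyl on this ester oxygen moves the result the opposite way from the earlier change: a 2.6-fold lower number from compound 1 to compound 3 (0.42 log units; beyond the scatter) stands against a 2.1-fold higher number from compound 1 to compound 2 (0.33 log units; beyond the scatter), so a larger group here does not always weaken inhibition. The direction therefore depends on which group enters, not simply on methyl being replaced. Nothing shown explains this difference.

As far as these compounds go, whether the ring itself matters, or only the number of carbons, stays open, and a straight pentyl chain on the same oxygen would separate the two. A cyclohexyl ring there would show whether the trend continues with a larger ring.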